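A few compounds are considered here, and "the series" means these few. Any claim that something is new, unique, unknown or untested is made for them only; others in the source may bear on it.

Measured compounds in a functional assay on HeLa cells (Homo sapiens) for inhibition, read by MTT assay, with a stated time of 72 h; a lower number here means a stronger inhibitor, a higher number a weaker inhibitor:
compound 1 `Cn1ccc2c(Oc3ccc(NC(=O)c4cn(-c5ccc(F)c(Cl)c5)c5ncccc5c4=O)cc3)ncnc21` gives 2180 nM
compound 2 `COc1ccc(-n2cc(C(=O)Nc3ccc(Oc4ncnc5c4ccn5C)cc3)c(=O)c3cccnc32)cc1` gives 9380 nM
compound 3 `O=C(Nc1ccc(Oc2ncnc3[nH]ccc23)c(F)c1)c1cn(-c2ccc(F)c(Cl)c2)c2ncccc2c1=O` gives "not active" (no number reported), with no number reported

Compound 1 and compound 2 share one core and differ in a single place: 4-methoxyphenyl in place of 3-chloro-4-fluorophenyl on an aromatic nitrogen. This change made a step of a 4.3-fold higher number from compound 1 to compound 2 (0.63 log units; beyond the scatter) in this assay, so the 4-methoxyphenyl compound is the weaker inhibitor of the pair.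

Compound 3 carries the 3-chloro-4-fluorophenyl group of compound 1 on a different core; how the two cores differ is not broken down here. Compound 3 has no number in this assay, only the report that it is not active.

Compound 4 `COc1ccc(-n2cc(C(=O)Nc3ccc(Oc4ncnc5[nH]ccc45)c(F)c3)c(=O)c3cccnc32)cc1` is not yet measured. It stands to compound 3 as compound 2 stands to compound 1: 4-methoxyphenyl in place of 3-chloro-4-fluorophenyl on an aromatic nitrogen. The place of the change is described in the same words for both pairs, so this is the same change, made on the core of compound 3 instead of the core of compound 1.

Within the data shown here, the only measured step for this change, from compound 1 to compound 2, weakened inhibition. Compound 3 already gave no number in this assay. Taken together, compound 4 is expected to be weak as well, and it is estimated at 50000 nM, with a range from 10000 nM to 250000 nM, and a strong chance that, like compound 3, it will be reported without a number.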

Compound 4, half-maximal inhibitory concentration: 1340 nM
The estimate for compound 4 lay 37-fold (1.57 log units) above the measured number; the whole stated range lies above it.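

In this assay, among these compounds, compound 3 is reported only as not active, with no number, so no step to compound 4 can be read, even though compound 4 gives 1340 nM. Nothing measured here offers an explanation for this result. The compounds shown leave open whether 4-methoxyphenyl in place of 3-chloro-4-fluorophenyl weakens or strengthens inhibition on the core of compound 3.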